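A few compounds are considered here, and "the series" means these few. Any claim that something is new, unique, unknown or untested is made for them only; others in the source may bear on it.

Measured so far:
- Compound 1 `CC(C)=CCn1c(CN2CCN(C(=O)C3CC3)CC2)nc2ccccc21`: 74.3%
- Compound 2 `O=C(C1CC1)N1CCN(Cc2nc3ccccc3n2Cc2cccc(F)c2)CC1`: 27.2%

Both compounds share one core and differ only in the group on a saturated chain carbon bound to an aromatic nitrogen. In an assay on isolated protein for inhibition of aldehyde dehydrogenase 1A1 (Homo sapiens), read by spectrophotometry, tested at 10 uM (on this read-out lower numbers stand for less inhibition and higher numbers for more inhibition at the one concentration tested (going by the name of the read-out)), compound 1 gives 74.3%, while compound 2 gives 27.2%, the lower of the two numbers measured. For the measured compounds named here, the single step between them, a number 47.1 percentage points lower from compound 1 to compound 2 (beyond the scatter), shows how much this position matters.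

Compound 3 `CC(C)CCn1c(CN2CCN(C(=O)C3CC3)CC2)nc2ccccc21` has not yet been measured. Its change from compound 2 is isobutyl in place of 3-fluorophenyl on a saturated chain carbon bound to an aromatic nitrogen. This replaces the aromatic ring with a branched saturated chain that resembles the 2-methylprop-1-en-1-yl group of compound 1 but without the double bond. Going by the values given here, the one relevant step, a number 47.1 percentage points lower from compound 1 to compound 2 (beyond the scatter), ran the other way: exchanging a branched chain for the 3-fluorophenyl group cost a large amount. Going back to a branched chain is therefore expected to recover much of that, with the step of a number 34.8 percentage points higher from compound 2 to compound 3 (beyond the scatter) expected in the upward direction. The saturated chain is not identical to that of compound 1, so the estimate is kept a little short of compound 1 and given a wide range.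

Compound 3 is expected to reach about 62%, between 38% and 80%.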

Compound 3, a percentage reported as inhibition, at one concentration (the size of the read-out at that concentration, not a potency): 70%
The estimate for compound 3 lay 8 percentage points below the measured number; low and high end bracket the measured number.
By their numbers in this assay, from the lowest: compound 2; then compounds 3 and 1 (each within the scatter of the next).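

With isobutyl on a saturated chain carbon bound to an aromatic nitrogen, this assay gives a number 42.8 percentage points higher from compound 2 to compound 3 (beyond the scatter) and so shows that the loss seen with 3-fluorophenyl can be undone by a change at this place alone, with the rest of the molecule left as it is. The double bond of compound 1 proves not to be needed to hold the read-out, since the step to the saturated chain is a number 4.3 percentage points lower from compound 1 to compound 3 (within the scatter) and the two branched chains cannot be told apart in this assay. No measurement available here explains why the two branched chains and the 3-fluorophenyl group give such different numbers.

With one aromatic example, the compounds shown leave open whether the low number of compound 2 goes with the ring itself or with its fluorine, a question that a plain phenyl group at this place could address. They also leave open whether the number would be higher, lower or level with other chains, for example a straight butyl chain, a longer chain, or a chain ending in an amine.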